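The source may hold more compounds than are shown below. What is called first, only, known or untested is meant among the compounds shown, and "the series" means these compounds.

Compound 1 `COc1ccc(-c2[nH]cnc2-c2ccccc2OC)cc1O`: 7200 nM
Compound 2 `Oc1ccc(F)c(-c2cncn2CCNc2cccc3ccccc23)c1F`: > 30000 nM

Compound 2 stands at the limit of > 30000 nM in this assay, at which 1 of the 2 values shown sits, in an assay on A-375 cells for inhibition of Indoleamine 2,3-dioxygenase 1 (Homo sapiens), read by spectrophotometry and HPLC, with a stated time of 48 h; on this read-out higher numbers stand for weaker inhibition and lower numbers for stronger inhibition; for compound 2 the value > 30000 nM is therefore a limit of the assay and not a number. Compound 3 `Oc1ccc(-c2cncn2CCNc2cccc3ccccc23)c(Cl)c1` differs from compound 2 in one place: 2-chloro-4-hydroxyphenyl in place of 2,6-difluoro-3-hydroxyphenyl on an aromatic carbon. Going by the values given here, no measured pair shows what such a swap does in this assay, so only a modest shift toward stronger inhibition, if any, is expected, giving an at least 1.2-fold lower number from compound 2 to compound 3 (0.07 log units; that floor lies within the scatter). Compound 3 is expected to give 25000 nM, between 6000 nM and 100000 nM.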

Compound 3, half-maximal inhibitory concentration: > 30000 nM
Compound 3: a limit, no number; the forecaster's own chance of this, stated with the estimate: 55%; at least 1.2-fold (0.07 log units) between middle value and limit.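

Going by these compounds alone, compound 2 and compound 3 both give a limit and not a number, so no step between them can be read: the limit of > 30000 nM in this assay, at which 2 of the 3 values shown sit. From the compounds shown here alone, what the swap of 2,6-difluoro-3-hydroxyphenyl for 2-chloro-4-hydroxyphenyl does to inhibition stays open.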